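A few compounds are considered here, and "the series" means these few. Any claim that something is new, unique, unknown or untested is made for them only; others in the source may bear on it.

Compound 1 `Nc1sc2c(c1-c1nc3cc(Cl)ccc3s1)CCC2`: 75.1 ug/mL
Compound 2 `Clc1ccc(/C=N/c2sc3c(c2-c2nc4ccccc4s2)CCC3)c(Cl)c1`: 345 ug/mL
Compound 3 `Fc1ccc(/C=N/c2sc3c(c2-c2nc4ccccc4s2)CCCC3)cc1`: 277 ug/mL

These three compounds were tested in an ADME assay on HeLa cells (Homo sapiens) for cytotoxicity, read by MTT assay, with a stated time of 72 h; a higher number here means that more compound is tolerated, a lower number that less compound is tolerated. Compound 3 gives 277 ug/mL, the second highest of the three numbers. Its nearest neighbour is compound 2 with 345 ug/mL, a gap that lies within the scatter of repeated measurements, so the two cannot be told apart. The furthest is compound 1 with 75.1 ug/mL, a gap that lies beyond the scatter, so compound 1 is tolerated less well than compound 3.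

Compound 4 `C(=C/c1ccccc1)\C=N\c1sc2c(c1-c1nc3ccccc3s1)CCCC2` has not yet been measured in this assay. It differs from compound 3 in one place: 2-phenylethenyl in place of 4-fluorophenyl on a carbon with a double bond to nitrogen. For the measured compounds named here, no step between two measured compounds that differ in only one place is available, so there is no direct measured guide for what this change does. Compounds 2 and 3 carry different substituted phenyl groups and differ in their core as well, and yet give values within the scatter of each other, which suggests that such changes move the number little. The expectation for compound 4 is therefore no step beyond the scatter, a 1.1-fold lower number from compound 3 to compound 4 (0.04 log units; within the scatter). Compound 4 is estimated at 250 ug/mL, with a range from 120 ug/mL to 500 ug/mL.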

Compound 4, half-maximal cytotoxic concentration: 389 ug/mL
Beside the measured number, compound 4's estimate is 1.6-fold (0.19 log units) below it, within the range that was stated.
By their numbers in this assay, from the lowest: compound 1; then compounds 3, 2 and 4 (each within the scatter of the next).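

In this assay, for the compounds shown here, putting 2-phenylethenyl in place of 4-fluorophenyl on a carbon with a double bond to nitrogen gives a 1.4-fold higher number from compound 3 to compound 4 (0.15 log units; within the scatter), and this is the first comparison here in which only that one place differs. At this position, then, a ring group bearing fluorine and an all-carbon group with a double bond outside the aromatic ring give numbers that cannot be told apart in this cell test, although the pair shows this for one exchange on one core only. No supporting measurement is available to explain why the number stays within the scatter, so the result stands as an observation without a cause.

These compounds leave open whether a carboxylic acid or a longer saturated chain on that same carbon would move the number beyond the scatter. They also leave open what lies behind the value of compound 1 , 75.1 ug/mL, since that compound differs from each of the others in more than one place and its number cannot be assigned to any single change.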